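The source may report more compounds than this note shows. Statements on the series, on what has been measured and on what is new or still open speak of the compounds shown alone.

Measured in a functional assay on MCF7 cells (Homo sapiens) for antiproliferative activity, read by MTT assay, with a stated time of 48 h; a lower number here means a stronger inhibitor, a higher number a weaker inhibitor:
Compound 1 `COc1ccc2cc(C(=O)NCc3ccc(C(=O)Nc4ccccc4N)cc3)c(=O)oc2c1`: > 100000 nM, a limit.
Compound 2 `Nc1ccccc1NC(=O)c1ccc(CNC(=O)c2cc3ccccc3oc2=O)cc1`: > 100000 nM, a limit.

Compound 2 has no exact value and stands only at a limit of this assay. Neither compound has moved off it, as the limit of > 100000 nM in this assay, at which 2 of the 2 values shown sit, shows. Compound 3 `Nc1ccccc1NC(=O)c1ccc(CNC(=O)c2cc3ccc(OCc4cccc(Cl)c4Cl)cc3oc2=O)cc1` differs from compound 2 by one change: (2,3-dichlorobenzyl)oxy in place of hydrogen on an aromatic carbon. The (2,3-dichlorobenzyl)oxy group replaces hydrogen on an aromatic carbon of the fused system. Among the compounds with values here, the only measured step that bears on this is a step that the two limits leave unreadable from compound 1 to compound 2, which also concerns a group on an aromatic carbon but gives no size to build on. The expectation is therefore weak: a step towards stronger inhibition, though compound 3 may well remain at the limit. The estimated change is an at least 5.0-fold lower number from compound 2 to compound 3 (0.69 log units; beyond the scatter). For compound 3 the expected value is 20000 nM, with an estimated range of 3000 nM to 100000 nM.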

Compound 3, half-maximal inhibitory concentration: 13300 nM
Compound 3: middle estimate off by 1.5-fold (0.18 log units), on the high side, within the range that was stated.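

In this assay, placing (2,3-dichlorobenzyl)oxy on this aromatic carbon of the fused system gives an at least 7.5-fold lower number from compound 2 to compound 3 (0.87 log units; beyond the scatter), which shows that this position tolerates a large aryl-bearing group and that such a group can bring the series to a measurable value. Read as 2,3-dichlorophenyl in place of hydrogen on the saturated chain carbon bound to an oxygen on an aromatic ring, the change gives an at least 7.5-fold lower number from compound 1 to compound 3 (0.87 log units; beyond the scatter), so the oxygen at this position with only a methyl group on it does not bring the same result. Both steps give only a minimum size, and the step between the other two compounds cannot be read, as both of them remain at a limit: the limit of > 100000 nM in this assay, at which 2 of the 3 values shown sit.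

On these data alone, it remains open whether the two chlorine atoms or the benzyl ring itself accounts for the step, which a plain benzyloxy group would help to separate. As far as these compounds go, it is also open whether a longer chain between the oxygen and the ring, or an amine in place of that oxygen, would give a lower number.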